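Swapping a benzoyl for a sulfonyl on the pyrazoline nitrogen

This account rests on a few compounds, and the source may have more. Where it says the series, first, only, none or still open, it means among the compounds named here.

The measured compounds so far:
Compound 1 `CC1=NN(C(=O)COc2ccc(Cl)cc2)C(c2cc(Br)cc(Br)c2O)C1` gives 40200 nM in a functional assay on PC-3 cells (Homo sapiens) for cytotoxicity, read by MTT assay, with a stated time of 48 h; on this read-out higher numbers stand for weaker inhibition and lower numbers for stronger inhibition.
Compound 2 `CC(=O)Oc1ccccc1C1CC(C)=NN1C(=O)CCl` gives 3580 nM in this assay.
Compound 3 `O=C(c1ccccc1)N1N=C(c2cc3ccccc3oc2=O)CC1c1ccccc1` gives 5870 nM in this assay.

Compound 3 has the second highest number of the three in this assay. Its nearest neighbour is compound 2, whose number lies within the usual scatter of compound 3, so the two cannot be told apart on these data. Compound 1 lies furthest away, with a number clearly beyond the scatter, so compound 1 is the weaker inhibitor of that pair.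

Compound 4 `Cc1ccc(S(=O)(=O)N2N=C(c3cc4ccccc4oc3=O)CC2c2ccccc2)cc1` has not yet been measured. It differs from compound 3 in one place: (4-methylphenyl)sulfonyl in place of benzoyl on an amine nitrogen in a ring. Within the data shown here, no step between two measured compounds mirrors this change, so there is nothing to lean on beyond the number of compound 3 itself and the fact that compounds 2 and 3 share a similar five-membered ring carrying an acyl group on nitrogen. With so little to go on, the step from compound 3 to compound 4 is expected to be small, in either direction, and most likely not beyond the scatter a 1.2-fold lower number from compound 3 to compound 4 (0.07 log units; within the scatter). Compound 4 is therefore estimated at 5000 nM in this assay, within a range of 1500 nM to 16000 nM.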

Compound 4, half-maximal inhibitory concentration: 48600 nM
Compound 4: the middle estimate sits 9.7-fold (0.99 log units) below what was measured, outside the stated range (above it).
By their numbers in this assay, from the lowest: compounds 2 and 3 (each within the scatter of the next); then compounds 1 and 4 (each within the scatter of the next).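

The group on the amine nitrogen in the ring clearly matters on this shared core: in this assay, putting (4-methylphenyl)sulfonyl in place of benzoyl gives an 8.3-fold higher number from compound 3 to compound 4 (0.92 log units; beyond the scatter), a step beyond the scatter. Both groups carry one six-membered aromatic ring of carbon only, so having that ring at this position is not enough to keep the number low. The data at hand give no explanation for the rise, so the reason remains unknown.

This single change swaps the carbonyl link for a sulfonyl link and also adds a methyl group to the aromatic ring, so the compounds shown cannot say which part accounts for the step; phenylsulfonyl or 4-methylbenzoyl at the same position would separate the two. From the compounds shown here alone, it also remains open how this position responds to groups of a different kind, such as a longer chain ending in an amine, and whether any such group would bring the number lower than that of compound 3.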